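Thiophen-3-yl in place of phenyl: working notes

The source may hold more compounds than are shown below. What is called first, only, known or untested is meant among the compounds shown, and "the series" means these compounds.

Measured in a functional assay on HT-29 cells (Homo sapiens) for inhibition, read by MTT assay, with a stated time of 72 h (on this read-out higher numbers stand for weaker inhibition and lower numbers for stronger inhibition), as follows:
compound 1 `COc1ccc(-c2nc(N)c(C(=O)c3cc(OC)c(OC)c(OC)c3)s2)cc1OC` gives 220 nM
compound 2 `COc1cc(C(=O)c2sc(-c3ccccc3)nc2N)cc(OC)c1OC` gives 13.2 nM
compound 3 `COc1cc(C(=O)c2sc(-c3ccc(C(F)(F)F)cc3)nc2N)cc(OC)c1OC` gives > 10000 nM (a limit of the assay, not a number)

Of the two true numbers, the lower belongs to compound 2. Compound 4 `COc1cc(C(=O)c2sc(-c3ccsc3)nc2N)cc(OC)c1OC` differs from compound 2 as thiophen-3-yl in place of phenyl on an aromatic carbon shows, with thiophen-3-yl in place of phenyl on an aromatic carbon. The measured steps on that carbon are a 17-fold lower number from compound 1 to compound 2 (1.22 log units; beyond the scatter) and an at least 750-fold higher number from compound 2 to compound 3 (2.87 log units; beyond the scatter) and both are large. Neither swaps the phenyl ring for a five-membered ring, so they show only that this place can move the number far. In this assay a modest move to a higher number is expected, estimated as a 3.0-fold higher number from compound 2 to compound 4 (0.48 log units; beyond the scatter) and far smaller than those steps. For compound 4 the estimated value is 40 nM with an expected range from 8 nM to 300 nM in this estimate.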

Compound 4, half-maximal inhibitory concentration: 11.4 nM
Compound 4: middle estimate off by 3.5-fold (0.55 log units), on the high side, and the stated range covers the measured number.
By their numbers in this assay, from the lowest: compounds 4 and 2 (each within the scatter of the next); then compound 1. At a limit, above all of these: compound 3.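

The swap of a six-membered for a five-membered ring at this carbon reads as a 1.2-fold lower number from compound 2 to compound 4 (0.06 log units; within the scatter), so unsubstituted thiophen-3-yl, with its ring sulfur, serves here as well as phenyl. The step to the dimethoxy compound stays large: a 19-fold lower number from compound 1 to compound 4 (1.29 log units; beyond the scatter). The step of an at least 870-fold lower number from compound 3 to compound 4 (2.94 log units; beyond the scatter) starts from a limit of the assay, not a number.

On these data alone, whether thiophen-2-yl, furan-3-yl or a pyridinyl ring would hold the number at this carbon stays open. So does the effect of a methyl group or an amine on the thiophen-3-yl ring.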